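A few compounds are considered here, and "the series" means these few. Any claim that something is new, unique, unknown or untested is made for them only; others in the source may bear on it.

- compound 1 `CCN1CCc2c(sc(NC(=O)Nc3ccc(Cl)cc3)c2C(N)=O)C1`: 3120 nM
- compound 2 `CCN1CCc2c(sc(NC(=O)Nc3cccc(C#N)c3)c2C(N)=O)C1`: 10300 nM
- compound 3 `CCN1CCc2c(sc(NC(=O)Nc3ccc(Cl)cc3Cl)c2C(N)=O)C1`: not yet measured

Among the compounds with values here, in a functional assay (strain AB) with Danio rerio as the target, read by microscopy, with a stated time of 1 h (on this read-out lower numbers stand for an effect already at smaller amounts and higher numbers for an effect only at larger amounts of compound), compound 2 holds the higher of the two numbers, at 10300 nM, and its only neighbour, compound 1, gives 3120 nM. Going on to compound 3 brings one change: 2,4-dichlorophenyl in place of 3-cyanophenyl on an amide-type nitrogen. In words, 2,4-dichlorophenyl comes in place of 3-cyanophenyl on an amide-type nitrogen. Within the data shown here, only one measured step bears on this: a 3.3-fold higher number from compound 1 to compound 2 (0.52 log units; beyond the scatter), a modest change beyond the scatter, in which 3-cyanophenyl replaced 4-chlorophenyl at the same place. Compound 3 returns to a chlorinated phenyl, so a modest step of similar size toward a lower number is expected in this assay. Among the measured compounds shown here, no measured step shows what the additional chlorine does, which keeps the range wide. The expected change is a 3.4-fold lower number from compound 2 to compound 3 (0.54 log units; beyond the scatter). For compound 3 the estimate is 3000 nM, with an expected range from 1000 nM to 9000 nM.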

Compound 3, half-maximal effective concentration: 11500 nM
Beside the measured number, compound 3's estimate is 3.8-fold (0.58 log units) below it; measured number outside the range, above it.
By their numbers in this assay, from the lowest: compound 1; then compounds 2 and 3 (each within the scatter of the next).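

In this assay, 2,4-dichlorophenyl on the amide-type nitrogen in place of 3-cyanophenyl gives a 1.1-fold higher number from compound 2 to compound 3 (0.05 log units; within the scatter) with no separation between the two, so a chlorinated phenyl at this place does not in itself bring the number back to that of compound 1. The added chloro in place of hydrogen on an aromatic carbon gives a 3.7-fold higher number from compound 1 to compound 3 (0.57 log units; beyond the scatter) and so leaves compound 1 as the only one of the three set apart from the others. Nothing measured here gives a reason for either step.

The compounds shown leave open whether 2-chlorophenyl alone would behave like 2,4-dichlorophenyl and how an unsubstituted phenyl would compare with 4-chlorophenyl. They also leave open what a methoxy group or an amine on the phenyl ring would do at this place.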